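This account rests on a few compounds, and the source may have more. Where it says the series, first, only, none or still open, it means among the compounds named here.

Working notes on the series. The shared core carries a methylamino group on one ring and a ribose on the five-membered ring; the substituent on the aromatic carbon of that five-membered ring is what varies. Compound 1 `CNc1ncnc2c1c(-c1cccs1)cn2[C@@H]1O[C@H](CO)[C@@H](O)[C@H]1O` bears thiophen-2-yl. In a functional assay on CEM-DNR-bulk cells (Homo sapiens), read by MTT assay, with a stated time of 72 h (a lower number here means a stronger inhibitor, a higher number a weaker inhibitor), compound 1 gives only a limit, > 20000 nM. Compound 2 `CNc1ncnc2c1c(-c1ccoc1)cn2[C@@H]1O[C@H](CO)[C@@H](O)[C@H]1O` bears furan-3-yl in place of thiophen-2-yl. In this assay compound 2 likewise gives only a limit, > 20000 nM. The step that the two limits leave unreadable from compound 1 to compound 2 therefore cannot be read, and both measured values sit at the limit of > 20000 nM in this assay, at which 2 of the 2 values shown sit. Compound 2 thus stands at the limit of this assay, with no number behind it.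

Compound 3 `CNc1ncnc2c1c(I)cn2[C@@H]1O[C@H](CO)[C@@H](O)[C@H]1O` differs from compound 2 by iodo in place of furan-3-yl on an aromatic carbon. Going by the values given here, no measured step bears on this change: the single step in hand is unreadable, and no compound carrying iodo has been measured. The expectation for compound 3 is therefore not anchored by any shown step; on the values of compound 1 and compound 2 alone, compound 3 is expected to remain near the limit in this assay, with the step of an at least 1.6-fold lower number from compound 2 to compound 3 (0.22 log units; that floor lies within the scatter) only a guess. Compound 3 is estimated at 12000 nM, within 1500 nM to 20000 nM.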

Compound 3, half-maximal inhibitory concentration: > 20000 nM
Compound 3: only a limit was reported; the forecaster's own chance of this, stated with the estimate: 55%; at least 1.6-fold (0.22 log units) between middle value and limit.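

In this assay compound 3 gives only a limit, > 20000 nM. No new step can be read from compound 1 or compound 2 to compound 3, and the series stays at a single limit: the limit of > 20000 nM in this assay, at which 3 of the 3 values shown sit. The compounds shown leave open how thiophen-2-yl, furan-3-yl and iodo rank against one another in this assay.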